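Swapping Nitro for Methoxy on a Sulfonamide Phenol

The compounds below may be only part of what the source reports. "The series", "measured", "known", "first", "only" and "open" are said of these compounds alone.

Compound 1 `Cc1cc(C)c(S(=O)(=O)Nc2ccc(O)cc2C)c(C)c1`: 51.5%
Compound 2 `Cc1cc(O)cc(C)c1NS(=O)(=O)c1ccc([N+](=O)[O-])cc1`: 58.4%
Compound 3 `Cc1ccc(S(=O)(=O)Nc2cc(C)c(O)cc2C)cc1`: 66.7%

All three were tested in an assay on isolated protein for inhibition of cytohesin-2 (Homo sapiens), read by fluorescence, tested at 1 mM; on this read-out lower numbers stand for less inhibition and higher numbers for more inhibition at the one concentration tested (going by the name of the read-out). Compound 2 stands second highest of the three numbers, but its gap to compound 1 and its gap to compound 3 both lie within the usual scatter, so the three cannot be ranked on these values. Compound 4 `COc1ccc(S(=O)(=O)Nc2c(C)cc(O)cc2C)cc1` has not yet been measured. It differs from compound 2 in one place: methoxy in place of nitro on an aromatic carbon. Among the measured compounds shown here, no pair of measured compounds isolates this change, so the data give no direction for it. For compound 4 the estimated step of a number 3.4 percentage points lower from compound 2 to compound 4 (within the scatter) is expected to stay within the scatter. Compound 4 is estimated at 55% in this assay, within a range from 35% to 75%.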

Compound 4, a percentage reported as inhibition, at one concentration (the size of the read-out at that concentration, not a potency): 32.1%
Compound 4: the middle estimate sits 22.9 percentage points above what was measured; the whole stated range lies above it.
By their numbers in this assay, from the lowest: compound 4; then compounds 1, 2 and 3 (each within the scatter of the next, the first and the last beyond it).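

In this assay the group on this aromatic carbon, para to a large group, clearly matters: methoxy in place of nitro gives a number 26.3 percentage points lower from compound 2 to compound 4 (beyond the scatter). The earlier compounds shown here differ from one another in more than one place, so they could not isolate any single change, whereas this pair shows that the result at this position depends on which group sits there. Nothing available explains the drop.

On these data alone, only nitro and methoxy are compared at this position, so it remains open how an amine or a carboxylic acid there would read. As far as these compounds go, whether the same swap gives a similar step on a differently substituted core also remains open.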